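The compounds below may be only part of what the source reports. "The series", "measured", "known", "first", "only" and "open" are said of these compounds alone.

Measured so far in an ADME assay on J774.A1 cells (Mus musculus) for cytotoxicity, read by MTT assay, with a stated time of 48 h; a lower number here means that less compound is tolerated, a higher number that more compound is tolerated:
- compound 1, `CCOC(=O)c1[nH]c(=O)c(C#N)cc1C(=O)c1ccccc1`: compound 1 gives 215000 nM
- compound 2, `CCOC(=O)c1[nH]c(=O)c(C#N)cc1C(=O)c1ccc(Cl)cc1`: compound 2 gives < 100000 nM, which is a limit of the assay, not a number

For the measured compounds named here, the one measured step, hydrogen to chloro on the aromatic carbon, gave an at least 2.1-fold lower number from compound 1 to compound 2 (0.33 log units; beyond the scatter). Compound 2 therefore stands only at the limit of < 100000 nM in this assay, at which 1 of the 2 values shown sits; where it lies beneath that limit is not known.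

Compound 3, `CCOC(=O)c1[nH]c(=O)c(C#N)cc1C(=O)c1ccc(C)cc1`, differs from compound 2 by methyl in place of chloro on an aromatic carbon. Going by the values given here, no measured pair exchanges chloro for methyl, so the step from compound 1 to compound 2 is the only one that bears on it, and it bears only indirectly: it shows that the para position is sensitive to substitution, but not how methyl compares with chloro. The expectation is that compound 3 stays in the region of compound 2, with an at least 1.1-fold higher number from compound 2 to compound 3 (0.04 log units; that floor lies within the scatter) as the estimated step, and that the number could again fall at the limit.

Compound 3 is estimated at 110000 nM in this assay, within 45000 nM to 260000 nM.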

Compound 3, half-maximal cytotoxic concentration: 194000 nM
Compound 3: middle estimate off by 1.8-fold (0.25 log units), on the low side; low and high end bracket the measured number.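

In this assay, methyl in place of chloro at this position gives an at least 1.9-fold higher number from compound 2 to compound 3 (0.28 log units; that floor lies within the scatter), so the drop seen with chloro does not simply carry over to every group placed there, although that floor alone does not settle the size of the change. Methyl in place of hydrogen gives a 1.1-fold lower number from compound 1 to compound 3 (0.04 log units; within the scatter), which places compound 1 and compound 3 within the scatter of each other, so adding a group on this carbon does not by itself shift the number. Compound 2 is read only as a limit, not a number: the limit of < 100000 nM in this assay, at which 1 of the 3 values shown sits.

Going by these compounds, how far the chloro step really extends remains open, and with only chloro and methyl at this position no trend across groups can be drawn. An amine, a carboxylic acid or a longer chain on the same aromatic carbon could show whether chloro stands alone in this series.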